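This account rests on a few compounds, and the source may have more. Where it says the series, first, only, none or still open, it means among the compounds named here.

Measured in a functional assay on HeLa cells (Homo sapiens) for cytotoxicity, read by ELISA, with a stated time of 2 days; on this read-out higher numbers stand for weaker inhibition and lower numbers for stronger inhibition:
Compound 1 `Oc1ccc(-c2cc(-c3ccccc3)cc(-c3ccco3)n2)cc1`: 10900 nM
Compound 2 `Oc1cccc(-c2cc(-c3ccccc3)nc(-c3ccccc3)c2)c1`: 15100 nM

For the measured compounds named here, compound 2 stands within the scatter of compound 1, the only other measured compound, so the two numbers set no order. The next structure is compound 3 `Oc1cccc(-c2cc(-c3ccccc3)nc(-c3cccnc3)c2)c1`, which carries pyridin-3-yl in place of phenyl on an aromatic carbon of compound 2 (pyridin-3-yl in place of phenyl on an aromatic carbon).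

Going by the values given here, no pair of measured compounds differs in one place only, so the size of this change has no direct precedent. Among the compounds with values here, the only guide is the close agreement of compound 1 at 10900 nM and compound 2 at 15100 nM, although they differ in more than one place. In this assay, no shift beyond the scatter is expected, and the estimated step of a 1.3-fold lower number from compound 2 to compound 3 (0.10 log units; within the scatter) is correspondingly small. For compound 3 the estimated value is 12000 nM, with an expected range of 5000 nM to 30000 nM.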

Compound 3, half-maximal inhibitory concentration: 17500 nM
For compound 3 the middle estimate is 1.5-fold (0.16 log units) below the measured one; the measured number falls inside the stated range.
By their numbers in this assay, from the lowest: compounds 1, 2 and 3 (each within the scatter of the next).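

In this assay, pyridin-3-yl in place of phenyl on the aromatic carbon next to the ring nitrogen gives a 1.2-fold higher number from compound 2 to compound 3 (0.06 log units; within the scatter), the only single-place comparison among the compounds shown. At this position, a ring with one hydrogen-bond acceptor and a ring of carbon only, each of 6 heavy atoms, cannot be told apart on this read-out. No supporting measurement bears on this result.

As far as these compounds go, whether the position gives a step beyond the scatter with a different kind of group, such as an amine, a carboxylic acid or pyridin-4-yl, stays open. The 3-hydroxyphenyl group and the remaining phenyl group have no single-place comparison here, so what each contributes in this assay cannot be read.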